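Bromo in place of hydrogen on compound 2

The source may hold more compounds than are shown below. What is called first, only, known or untested is meant among the compounds shown, and "the series" means these compounds.

Among the measured compounds shown here, in a functional assay on K562 cells (Homo sapiens) for cytotoxicity, read by XTT assay, with a stated time of 24 h (a higher number here means a weaker inhibitor, a lower number a stronger inhibitor), compound 1 `COc1ccc(C(=O)Nc2ccc(C)c(Nc3nccc(-c4cccnc4)n3)c2)cc1OCCCCn1ccnc1` gives 10100 nM and compound 2 `Cc1ccc(NC(=O)c2cccc(OCCCCn3ccnc3)c2)cc1Nc1nccc(-c2cccnc2)n1` gives 74600 nM as the higher of the two numbers so far. Compound 3 `Cc1ccc(NC(=O)c2cc(Br)cc(OCCCCn3ccnc3)c2)cc1Nc1nccc(-c2cccnc2)n1` has bromo in place of hydrogen on an aromatic carbon of compound 2 (bromo in place of hydrogen on an aromatic carbon). For the measured compounds named here, only one measured step bears on this: a 7.4-fold higher number from compound 1 to compound 2 (0.87 log units; beyond the scatter) with hydrogen in place of methoxy, modest but beyond the scatter. It concerns a different group, so it is thin support. Read in reverse, it points to a modest fall in this assay as the expectation. The expected step is a 3.0-fold lower number from compound 2 to compound 3 (0.47 log units; beyond the scatter) in that direction. For compound 3 the estimate is 25000 nM with an expected range of 8000 nM to 75000 nM in this assay.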

Compound 3, half-maximal inhibitory concentration: 6500 nM
Estimate against measurement, compound 3: 3.8-fold (0.59 log units) above; the whole stated range lies above it.
By their numbers in this assay, from the lowest: compounds 3 and 1 (each within the scatter of the next); then compound 2.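

Bromo in place of hydrogen on this aromatic carbon, meta to a 4-(1H-imidazol-1-yl)butoxy group, gives an 11-fold lower number from compound 2 to compound 3 (1.06 log units; beyond the scatter) in this assay as a large step. The change adds only 1 heavy atom, with no ring and 0 hydrogen-bond donors or acceptors, so this position responds strongly to a small substituent. Nothing measured here explains the size of the step.

On these data alone, whether chloro, an amine or a carboxylic acid on this carbon would give a similar fall remains open. So does whether the bromo step persists with a longer chain in place of the 4-(1H-imidazol-1-yl)butoxy group.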